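The source may report more compounds than this note shows. Statements on the series, on what has been measured and on what is new or still open speak of the compounds shown alone.

Compound 1 `O=C1C[C@H](O)C[C@@H](/C=C/c2c(Cl)cc(Cl)cc2-c2ccccc2)O1` gives 80 nM in an assay for inhibition of 3-hydroxy-3-methylglutaryl-coenzyme A reductase (Rattus norvegicus) (a higher number here means a weaker inhibitor, a lower number a stronger inhibitor), the lowest of the three numbers shown. Compound 2 `CO[C@H]1CC(=O)O[C@H](/C=C/c2c(C)cc(C)cc2-c2ccc(F)c(C)c2)C1` gives 106 nM in this assay, which lies within the usual scatter of compound 1, so no order between the two can be read. Compound 3 `O=C1C[C@H](O)C[C@@H](/C=C/c2c(F)cc(F)cc2-c2ccc(F)cc2)O1` gives 860 nM in this assay, a gap to compound 1 that lies beyond the scatter. Compound 4 `O=C1C[C@H](O)C[C@@H](/C=C/c2c(Cl)cc(Cl)cc2-c2ccc(Cl)c(Cl)c2)O1` has not been measured and differs from compound 1 by 3,4-dichlorophenyl in place of phenyl on an aromatic carbon. For the measured compounds named here, no measured pair isolates this change, so the step expected from it, a 1.3-fold higher number from compound 1 to compound 4 (0.10 log units; within the scatter), is small and not beyond the scatter in either direction, because compound 2 at 106 nM stays close to compound 1. Compound 4 is therefore estimated at 100 nM, with a range from 30 nM to 350 nM.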

Compound 4, half-maximal inhibitory concentration: 25 nM
The estimate for compound 4 lay 4.0-fold (0.60 log units) above the measured number, and the stated range ends above it.
By their numbers in this assay, from the lowest: compound 4; then compounds 1 and 2 (each within the scatter of the next); then compound 3.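

In this assay putting 3,4-dichlorophenyl in place of phenyl on this aromatic carbon gives a 3.2-fold lower number from compound 1 to compound 4 (0.51 log units; beyond the scatter) and so lies beyond the scatter. This is the first pair among the compounds shown that isolates a change at this position, and it shows that the larger group is accepted here with a modest gain. Nothing shown here accounts for that gain. As far as these compounds go, it remains open whether both chlorine atoms are needed for the step, and how an amine or a carboxylic acid on this ring would read.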